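Furan and Thiophene Amides Tested for Bladder Cell Toxicity

The source may report more compounds than this note shows. Statements on the series, on what has been measured and on what is new or still open speak of the compounds shown alone.

Compound 1, `C/C(=C\c1cc(-c2ccc(C)cc2)co1)C(N)=O`: in a functional assay on T-24 cells (Homo sapiens) for cytotoxicity, read by CCK-8 assay, with a stated time of 24 h (on this read-out lower numbers stand for stronger inhibition and higher numbers for weaker inhibition), compound 1 gives > 50000 nM, which is a limit of the assay and not a number.
Compound 2, `C/C(=C\c1cc(-c2ccc(F)cc2)co1)C(N)=O`: compound 2 gives > 50000 nM, again a limit.
Compound 3, `C/C(=C\c1cc(-c2ccc(C)cc2)cs1)C(N)=O`: compound 3 gives > 50000 nM, also a limit.

The change from compound 1 to compound 2 is fluoro in place of methyl on an aromatic carbon. Its step, a step that the two limits leave unreadable from compound 1 to compound 2, has no readable size because of the limit of > 50000 nM in this assay, at which 3 of the 3 values shown sit. The difference between the cores of compound 1 and compound 3 is not broken down here.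

Compound 4, `C/C(=C\c1cc(-c2ccc(F)cc2)cs1)C(N)=O`, has not yet been measured. Relative to compound 3 it carries the same change: fluoro in place of methyl on an aromatic carbon. The step from compound 3 to compound 4 in this assay is expected to be a step that the limit leaves unreadable from compound 3 to compound 4, resting on compound 3 and on (the limit of > 50000 nM in this assay, at which 3 of the 3 values shown sit). Compound 4 is estimated at 100000 nM, most likely reported once more only as a limit.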

Compound 4, half-maximal inhibitory concentration: > 50000 nM
Compound 4 ended at the assay's limit; the forecaster's own chance of this, stated with the estimate: 85%; the middle value lies beyond the limit too.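

For compound 3 and compound 4, the results are limits and not numbers, so the step between them cannot be read: the limit of > 50000 nM in this assay, at which 4 of the 4 values shown sit. The compounds shown leave open which structural change, if any, would give a measurable value.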